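This account rests on a few compounds, and the source may have more. Where it says the series, first, only, none or still open, it means among the compounds named here.

Of the compounds shown here, two built on a shared core have been tested in a functional assay on LM7 cells (Homo sapiens) for antiproliferative activity, read by MTT assay, with a stated time of 72 h; on this read-out lower numbers stand for stronger inhibition and higher numbers for weaker inhibition. Compound 1, with the structure `Cc1ccc2c(=O)c(CSC(=S)N3CCCCC3)coc2c1`, gives 5100 nM in this assay. Compound 2, with the structure `O=c1c(CSC(=S)N2CCOCC2)coc2cc(Cl)ccc12`, gives 6200 nM in this assay. Compound 2 shows the higher of the two numbers, yet its gap to compound 1 lies within the scatter, so the two cannot be told apart on potency. Compound 1 and compound 2 differ in two places at once, so no single step can be read between them.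

Compound 3, with the structure `O=c1c(CSC(=S)N2CCCCC2)coc2cc(Cl)ccc12`, has not yet been measured. It keeps the core of compound 2 and differs from it in one place: piperidin-1-yl in place of morpholin-4-yl on a thiocarbonyl carbon. The same piperidin-1-yl ring already appears in compound 1, whose value of 5100 nM sits within the scatter of compound 2. On that basis no step beyond the scatter is expected, perhaps a slight move toward a lower number. The expected step is a 1.4-fold lower number from compound 2 to compound 3 (0.14 log units; within the scatter). Compound 3 is estimated to give 4500 nM in this assay, with a range from 2000 nM to 10000 nM.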

Compound 3, half-maximal inhibitory concentration: 850 nM
Estimate against measurement, compound 3: 5.3-fold (0.72 log units) above, outside the stated range (below it).
By their numbers in this assay, from the lowest: compound 3; then compounds 1 and 2 (each within the scatter of the next).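

In this assay the group on the thiocarbonyl carbon matters: with the rest of the structure unchanged, piperidin-1-yl in place of morpholin-4-yl gives a 7.3-fold lower number from compound 2 to compound 3 (0.86 log units; beyond the scatter) beyond the scatter, even though both are six-membered rings and the leaving ring differs mainly in carrying an oxygen. For the compounds shown here, the aromatic carbon matters as well: with piperidin-1-yl held fixed, chloro in place of methyl gives a 6.0-fold lower number from compound 1 to compound 3 (0.78 log units; beyond the scatter) and this step is also beyond the scatter, so the closeness of the two earlier compounds, which differ in both places, gave no sign of either step. Nothing measured here accounts for why either change has this size.

As far as these compounds go, whether the ring change would give a similar step with methyl on the aromatic carbon, or the chloro change a similar step with morpholin-4-yl on the thiocarbonyl carbon, stays open, so the two steps cannot yet be called independent of each other. Also open, from the compounds shown here alone, is how other groups would behave, such as a pyrrolidin-1-yl or piperazin-1-yl ring on the thiocarbonyl carbon, or fluoro or methoxy on the aromatic carbon.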